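This account rests on a few compounds, and the source may have more. Where it says the series, first, only, none or still open, it means among the compounds named here.

Three compounds of the series have a number in a physicochemical assay for lipophilicity, read by HPLC, measured as octanol-water partition, at pH 7; a lower number here means a more polar compound, a higher number a more lipophilic compound. Compound 1 `Cc1cc(OC(=O)OCCCCCCO[N+](=O)[O-])n(-c2ccccc2)n1` gives 4.39. Compound 3 `Cc1cc(OC(=O)C(C)(C)CCCCO[N+](=O)[O-])n(-c2ccccc2)n1` gives 4.3, within the scatter of compound 1. Compound 2 `Cc1cc(OC(=O)C(C)(C)CO[N+](=O)[O-])n(-c2ccccc2)n1` gives 3.55, the lowest of the three numbers. The difference between the cores of compound 1 and compound 3 is not broken down here. Compound 2 arises from compound 3 by nitrooxy in place of 3-(nitrooxy)propyl on a saturated chain carbon, two bonds along the chain from a carbonyl carbon, and that change moves a number 0.75 log units lower from compound 3 to compound 2 (beyond the scatter). Compound 4 `Cc1cc(OC(=O)OCCCO[N+](=O)[O-])n(-c2ccccc2)n1` is not yet measured; it arises from compound 1 by nitrooxy in place of 3-(nitrooxy)propyl on a saturated chain carbon, three bonds along the chain from an oxygen next to a carbonyl group, the same kind of change, although the place differs: two bonds along the chain from a carbonyl carbon in compound 3, three bonds along the chain from an oxygen next to a carbonyl group in compound 1. Compound 4 is expected to show a step of a number 0.74 log units lower from compound 1 to compound 4 (beyond the scatter). This expectation rests on the measured step of a number 0.75 log units lower from compound 3 to compound 2 (beyond the scatter). Compound 4 is therefore estimated at 3.65, likely between 3.3 and 4.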

Compound 4, partition coefficient: 3.35
For compound 4 the middle estimate is 0.30 log units above the measured one; the measured number falls inside the stated range.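

In this assay the change from 3-(nitrooxy)propyl to nitrooxy gives a number 1.04 log units lower from compound 1 to compound 4 (beyond the scatter), the same direction as a number 0.75 log units lower from compound 3 to compound 2 (beyond the scatter), and both steps lie beyond the scatter. The change therefore carries in direction between these two cores, with its place differing between them, but two pairs establish no rule for any other core. No measurement shown here accounts for the size of either step.

Still open, on these data alone, is how the same change reads on a further core. Also open, as far as these compounds go, is what this assay would give with an amine or a carboxylic acid in place of the nitrooxy group on either core.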